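Para substituent swap on the benzamide of compound 2

The compounds below may be only part of what the source reports. "The series", "measured", "known", "first", "only" and "open" are said of these compounds alone.

compound 1 `O=C(Nc1cccc(-c2oc3cc(-c4ccc(F)cc4)ccc3c(=O)c2O)c1)c1ccccc1F`: 5630 nM
compound 2 `O=C(Nc1cccc(-c2oc3cc(-c4ccc(F)cc4)ccc3c(=O)c2O)c1)c1ccc(Cl)cc1`: 3670 nM
compound 3 `O=C(Nc1cccc(-c2oc3cc(-c4ccc(F)cc4)ccc3c(=O)c2O)c1)c1ccc(F)cc1F`: 10700 nM

Within the data shown here, in a functional assay on HeLa cells (Homo sapiens) for antiproliferative activity, read by CCK-8 assay, with a stated time of 72 h (on this read-out lower numbers stand for stronger inhibition and higher numbers for weaker inhibition), compound 2 gives the smallest number of the three, although the step of a 1.5-fold lower number from compound 1 to compound 2 (0.19 log units; within the scatter) stays within the scatter and only the step of a 2.9-fold higher number from compound 2 to compound 3 (0.46 log units; beyond the scatter) goes beyond it. Compound 4 `O=C(Nc1cccc(-c2oc3cc(-c4ccc(F)cc4)ccc3c(=O)c2O)c1)c1ccc(C(F)(F)F)cc1` is unmeasured and differs from compound 2 by trifluoromethyl in place of chloro on an aromatic carbon. Among the measured compounds shown here, no measured step exchanges a para group for another on this ring; the two steps that change the benzoyl ring, a 1.5-fold lower number from compound 1 to compound 2 (0.19 log units; within the scatter) and a 2.9-fold higher number from compound 2 to compound 3 (0.46 log units; beyond the scatter), were small to modest. The step from compound 2 to compound 4 is therefore expected to be a 1.1-fold higher number from compound 2 to compound 4 (0.04 log units; within the scatter), within the scatter. Compound 4 is estimated at 4000 nM, between 1500 nM and 11000 nM.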

Compound 4, half-maximal inhibitory concentration: 17400 nM
For compound 4 the middle estimate is 4.4-fold (0.64 log units) below the measured one; measured number above the stated range.
By their numbers in this assay, from the lowest: compounds 2, 1, 3 and 4 (each within the scatter of the next, the first and the last beyond it).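

In this assay this position of the benzoyl ring proves sensitive to the group it carries: with a 4.7-fold higher number from compound 2 to compound 4 (0.68 log units; beyond the scatter), replacing chloro with trifluoromethyl costs activity. Compound 4 also separates from the 2-fluorophenyl amide, with a 3.1-fold higher number from compound 1 to compound 4 (0.49 log units; beyond the scatter), whereas a 1.6-fold higher number from compound 3 to compound 4 (0.21 log units; within the scatter) leaves it level with the 2,4-difluorophenyl amide. Thus, the one clean exchange at this position moves the number beyond the scatter.

Nothing available gives a reason for this step. Going by these compounds, whether a methyl, a methoxy, an amine or a carboxylic acid at this position would stay near compound 2 remains open.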